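The compounds below may be only part of what the source reports. "The series", "measured", "known", "first", "only" and "open" are said of these compounds alone.

Measured so far:
- compound 1 `O=C(/C=C/c1ccc2c(c1)B(O)OC2)c1ccc(F)cc1` — 1400 nM
- compound 2 `O=C(/C=C/c1ccc2c(c1)B(O)OC2)c1ccccc1F` — 3700 nM

In a functional assay on SK-OV-3 cells (Homo sapiens) for cytotoxicity, read by MTT assay, with a stated time of 48 h (a higher number here means a weaker inhibitor, a lower number a stronger inhibitor), compound 2 gives 3700 nM, the higher of the two numbers recorded; compound 1 gives 1400 nM in this assay. Among the compounds with values here, the single measured step runs a 2.6-fold higher number from compound 1 to compound 2 (0.42 log units; beyond the scatter), a modest step that lies beyond the scatter.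

Compound 3 `O=C(/C=C/c1ccc2c(c1)B(O)OC2)c1cccc(F)c1` differs from compound 2 by 3-fluorophenyl in place of 2-fluorophenyl on a carbonyl carbon. Within the data shown here, the only step that bears on this is the one from compound 1 to compound 2, which moved the fluorophenyl substitution in the same part of the molecule and gave a modest rise in the number. Among the measured compounds shown here, a third arrangement of the same atoms has no direct precedent here; the two measured values set a band of roughly the same width.

Compound 3 is therefore expected near the middle of that band, with a step of a 1.7-fold lower number from compound 2 to compound 3 (0.23 log units; within the scatter) in this assay, and an estimated value of 2200 nM (range 1000 nM to 4800 nM).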

Compound 3, half-maximal inhibitory concentration: 4800 nM
Compound 3: the middle estimate sits 2.2-fold (0.34 log units) below what was measured; measured number inside the range.
By their numbers in this assay, from the lowest: compound 1; then compounds 2 and 3 (each within the scatter of the next).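

In this assay, 3-fluorophenyl and 2-fluorophenyl on the carbonyl carbon cannot be told apart (a 1.3-fold higher number from compound 2 to compound 3 (0.11 log units; within the scatter)). The 4-fluorophenyl of compound 1 now stands apart from both, as the second comparison (a 3.4-fold higher number from compound 1 to compound 3 (0.54 log units; beyond the scatter)) agrees with the earlier one (a 2.6-fold higher number from compound 1 to compound 2 (0.42 log units; beyond the scatter)), which makes compound 1 the most potent of the three and shows that this position responds to where the fluorine sits only in the case of 4-fluorophenyl. Nothing available accounts for this difference.

On these data alone, whether the advantage of compound 1 belongs to fluorine itself stays open; an unsubstituted phenyl, or a 4-chlorophenyl or 4-methoxyphenyl, on the carbonyl carbon would address that. Also open, as far as these compounds go, is how a group carrying an amine at this position would compare with the fluorophenyl compounds.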